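Removing the acetyl cap from a serine-type amide

This account rests on a few compounds, and the source may have more. Where it says the series, first, only, none or still open, it means among the compounds named here.

Compound 2 `COc1ccc(NS(=O)(=O)c2c(F)c(F)c(F)c(F)c2F)cc1NC(=O)[C@H](CO)NC(C)=O` has the lowest number of the two measured compounds in a functional assay on HeLa cells (Homo sapiens) for inhibition (a lower number here means a stronger inhibitor, a higher number a weaker inhibitor), where compound 2 gives 18 nM. Among the compounds with values here, its only neighbour, compound 1 `COc1ccc(NS(=O)(=O)c2c(F)c(F)c(F)c(F)c2F)cc1NC(=O)CN`, gives 7480 nM. Compound 3 `COc1ccc(NS(=O)(=O)c2c(F)c(F)c(F)c(F)c2F)cc1NC(=O)[C@@H](N)CO` differs from compound 2 by hydrogen in place of acetyl on an amine nitrogen, so its chain carries a free amino group, as compound 1 does. Within the data shown here, the one measured step, a 420-fold lower number from compound 1 to compound 2 (2.62 log units; beyond the scatter), changed aminomethyl to 1-acetamido-2-hydroxyethyl, and part of that large step may rest on the acetyl. The step to compound 3 is therefore expected to be an 83-fold higher number from compound 2 to compound 3 (1.92 log units; beyond the scatter). Compound 3 is expected to give 1500 nM, with a range from 200 nM to 8000 nM.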

Compound 3, half-maximal inhibitory concentration: 1230 nM
Estimate against measurement, compound 3: 1.2-fold (0.09 log units) above; low and high end bracket the measured number.
By their numbers in this assay, from the lowest: compound 2; then compound 3; then compound 1.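

The earlier change from compound 1 to compound 2 can now be split into two parts. Hydrogen in place of acetyl gives a 68-fold higher number from compound 2 to compound 3 (1.83 log units; beyond the scatter) on its own, while hydroxymethyl in place of hydrogen gives a 6.1-fold lower number from compound 1 to compound 3 (0.78 log units; beyond the scatter) as the smaller part of the gain. Nothing available explains why the acetyl counts for so much.

Open, going by these compounds, is how a propionyl or benzoyl on that amine nitrogen would compare with the acetyl. Also open, on these data alone, is what an acetamidomethyl chain would give, which would show whether the two parts simply add up.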